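The source may hold more compounds than are shown below. What is called first, only, known or untested is meant among the compounds shown, and "the series" means these compounds.

Three compounds that share one core and differ only in the amine at the end of the chain have been read in a functional assay on MCF7 cells (Homo sapiens) for antiproliferative activity, read by MTT assay, with a stated time of 72 h; on this read-out higher numbers stand for weaker inhibition and lower numbers for stronger inhibition. Here compound 1 `COc1cc2c(Nc3ccc(C#N)cc3)ncnc2cc1OCCCN(C)C` gives 45000 nM. Compound 3 `COc1cc2c(Nc3ccc(C#N)cc3)ncnc2cc1OCCCN1CCCCC1` gives 35100 nM. For compound 2 `CCN(CC)CCCOc1cc2ncnc(Nc3ccc(C#N)cc3)c2cc1OC`, the result is only a limit, > 100000 nM. Within the data shown here, compound 3 therefore stands level with compound 1, the only other compound with a true number: the step is a 1.3-fold lower number from compound 1 to compound 3 (0.11 log units; within the scatter).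

Compound 4 `COc1cc2c(Nc3ccc(C#N)cc3)ncnc2cc1OCCCN1CCC(C)CC1` takes compound 3 one change further: methyl in place of hydrogen on a saturated ring carbon. This is methyl in place of hydrogen on a saturated ring carbon, turning piperidin-1-yl into 4-methylpiperidin-1-yl. The measured steps all concern this same amine, though none adds a group to the ring. Changing the amine can move the number, as in an at least 2.2-fold higher number from compound 1 to compound 2 (0.34 log units; beyond the scatter) and an at least 2.8-fold lower number from compound 2 to compound 3 (0.45 log units; beyond the scatter). Both of these steps rest on (the limit of > 100000 nM in this assay, at which 1 of the 3 values shown sits). The exchange of dimethylamino for piperidin-1-yl goes against any general trend, since it stayed within the scatter. With so small an addition, no shift beyond the scatter is expected, and the expected step is a 1.0-fold lower number from compound 3 to compound 4 (0.00 log units; within the scatter). The estimate for compound 4 is 35000 nM, with an expected range of 14000 nM to 90000 nM.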

Compound 4, half-maximal inhibitory concentration: 43100 nM
Compound 4: middle estimate off by 1.2-fold (0.09 log units), on the low side; the range from low to high includes it.
By their numbers in this assay, from the lowest: compounds 3, 4 and 1 (each within the scatter of the next). At a limit, above all of these: compound 2.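

In this assay, among these compounds, compound 4 shows for the first time what a group added to the amine ring does: methyl on a saturated ring carbon, three ring bonds from the ring nitrogen, leaves the read-out level with compound 3 (a 1.2-fold higher number from compound 3 to compound 4 (0.09 log units; within the scatter)). The larger ring amine also stays level with the small dimethylamino group (a 1.0-fold lower number from compound 1 to compound 4 (0.02 log units; within the scatter)), so compounds 1, 3 and 4 form a level set, and in these compounds neither the ring nor its methyl sets them apart from one another. Among the compounds shown here, the result for compound 2 is a limit, so the only step of the three that lies beyond the scatter (an at least 2.3-fold lower number from compound 2 to compound 4 (0.36 log units; beyond the scatter)) gives a bound and not a size, and it rests on one value: the limit of > 100000 nM in this assay, at which 1 of the 4 values shown sits.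

The compounds shown leave open whether a group larger than methyl at this ring carbon, such as phenyl, or one carrying oxygen, such as hydroxyl, would shift the number beyond the scatter. They also leave open whether a different ring amine, such as morpholin-4-yl or 4-methylpiperazin-1-yl, or a longer chain to the amine would separate itself from this level set.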